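Swapping Ester Arm for Trifluoromethylphenyl: Cytotoxicity Outlook

The compounds below may be only part of what the source reports. "The series", "measured", "known", "first", "only" and "open" are said of these compounds alone.

Measured so far:
compound 1 `CN1CCN(CCNCc2cn(-c3ccc(F)cc3F)nc2-c2ccc(Cl)cc2)CC1`: 19000 nM
compound 2 `CCOC(=O)Cn1cc(CNCCN2CCN(C)CC2)c(-c2ccccc2C)n1`: reported only as a limit, > 20000 nM

In an ADME assay on Huh-7 cells (Homo sapiens) for cytotoxicity (a lower number here means that less compound is tolerated, a higher number that more compound is tolerated), compound 1 gives 19000 nM. Compound 2 is reported only as a limit in this assay, > 20000 nM, which places compound 2 at the top of what the assay reports, as described by the limit of > 20000 nM in this assay, at which 1 of the 2 values shown sits. Compound 3 `Cc1ccccc1-c1nn(-c2cccc(C(F)(F)F)c2)cc1CNCCN1CCN(C)CC1` differs from compound 2 by 3-(trifluoromethyl)phenyl in place of (ethoxycarbonyl)methyl on an aromatic nitrogen. Among the measured compounds shown here, no step between two measured compounds is available to gauge this change directly. Compound 1, which also carries an aromatic group on that nitrogen, gives 19000 nM in this assay. Compound 3 is therefore expected to sit near the top of this assay, with the step of an at least 1.2-fold lower number from compound 2 to compound 3 (0.09 log units; that floor lies within the scatter) amounting to no more than the usual scatter. The estimate for compound 3 is 16000 nM, within 7000 nM to 40000 nM.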

Compound 3, half-maximal cytotoxic concentration: 18000 nM
Compound 3: the middle estimate sits 1.1-fold (0.05 log units) below what was measured; the measured number falls inside the stated range.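

In this assay, among the compounds shown here, the first direct comparison at this aromatic nitrogen is an at least 1.1-fold lower number from compound 2 to compound 3 (0.04 log units; that floor lies within the scatter), with 3-(trifluoromethyl)phenyl in place of (ethoxycarbonyl)methyl. It shows that this position can carry an aromatic ring with more heavy atoms and no hydrogen-bond acceptors while compound 3 still gives a measured number close to the top of the reported range. Only a floor can be stated for this step, and its true size stays unknown, because the value for compound 2 is a limit: the limit of > 20000 nM in this assay, at which 1 of the 3 values shown sits.

The compounds shown leave open how a small alkyl group such as methyl, or an arm ending in a carboxylic acid or an amine, would read on this nitrogen in this assay. They also leave open whether a plain phenyl would read like 3-(trifluoromethyl)phenyl.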